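Changing the Amide Aryl Group: From Compound 1 to Compound 4

This account rests on a few compounds, and the source may have more. Where it says the series, first, only, none or still open, it means among the compounds named here.

Measured compounds:
Compound 1 `Cc1cc(C(=O)NCN2CCC(c3cccc[n+]3[O-])CC2)ccc1F`: 67%
Compound 2 `O=C(CN1CCC(c2cccc[n+]2[O-])CC1)Nc1ccc(F)cc1F`: 74%
Compound 3 `COc1cccc(C)c1NC(=O)CN1CCC(c2cccc[n+]2[O-])CC1`: 56%

Of the compounds shown here, three share a common core and have been tested in a functional assay on HEK293 cells for agonist activity at D(4) dopamine receptor (Homo sapiens), read by FLIPR; a higher number here means a larger maximal response, a lower number a smaller maximal response. Compound 1 gives 67%, the second highest of the three numbers. Compound 2 gives 74%, a value that lies within the usual scatter of compound 1. Compound 3 gives 56%, a number that lies below compound 1 by more than the scatter.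

Compound 4 `N#Cc1cccc(C(=O)NCN2CCC(c3cccc[n+]3[O-])CC2)c1` has not yet been measured. It differs from compound 1 in one place: 3-cyanophenyl in place of 4-fluoro-3-methylphenyl on a carbonyl carbon. Within the data shown here, no step between measured compounds that differ in a single place is known, so the size of this change in this assay has to be judged from the spread of the three values alone, which is modest. The account therefore expects a step from compound 1 to compound 4 of a number 3 percentage points lower from compound 1 to compound 4 (within the scatter), that is, no change beyond the scatter. For compound 4 the estimated value in this assay is 64%, with a range from 50% to 78%.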

Compound 4, largest response reached (reported as efficacy), in percent of the reference or control that the assay uses: 69%
For compound 4 the middle estimate is 5 percentage points below the measured one; the measured number falls inside the stated range.
By their numbers in this assay, from the lowest: compound 3; then compounds 1, 4 and 2 (each within the scatter of the next).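

Among these compounds, this is the first step that can be read at a single place. In this assay, 3-cyanophenyl in place of 4-fluoro-3-methylphenyl on a carbonyl carbon gives a number 2 percentage points higher from compound 1 to compound 4 (within the scatter), so this assay does not tell the two aryl groups apart, even though the entering group brings a nitrile and a hydrogen-bond acceptor that the leaving group lacks. Nothing at hand bears on why these two groups read alike.

One step cannot show whether other groups on this carbonyl carbon would also read alike, for example a phenyl ring carrying a carboxylic acid or a dimethylamino group, or a cyclohexyl ring in place of the aromatic ring. Going by these compounds, whether the same change would give a similar step on a different core also remains open.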